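This account rests on a few compounds, and the source may have more. Where it says the series, first, only, none or still open, it means among the compounds named here.

Of the compounds shown here, three built on one shared core have been tested in a functional assay on QGY7701 cells (Homo sapiens) for cytotoxicity, read by MTT assay, with a stated time of 24 h; a lower number here means a stronger inhibitor, a higher number a weaker inhibitor. In this assay compound 1 `C=CC1=C(C(=O)NCCCCC)C(c2ccc(OC)cc2)OC1` gives > 100000 nM, which is a limit of the assay rather than a number. In this assay compound 2 `C=CC1=C(C(=O)Nc2cccc(C)c2)C(c2ccc(F)cc2)OC1` gives 56400 nM. In this assay compound 3 `C=CC1=C(C(=O)NCc2ccccc2F)C(c2ccc(F)cc2)OC1` gives 51400 nM, the lowest of the two numbers, though the step of a 1.1-fold lower number from compound 2 to compound 3 (0.04 log units; within the scatter) keeps both within the scatter. Compound 4 `C=CC1=C(C(=O)NCCCCC)C(c2ccc(F)cc2)OC1` has not yet been measured. It differs from compound 3 in one place: butyl in place of 2-fluorophenyl on a saturated chain carbon bound to an amide-type nitrogen. Within the data shown here, only one step has been measured directly, and it exchanged one aromatic group for another without leaving the scatter, so it says little about removing the ring altogether. Compound 1 carries the same pentyl chain that compound 4 would carry, and its result, (the limit of > 100000 nM in this assay, at which 1 of the 3 values shown sits), is the nearest guide available. The expected step of a 2.3-fold higher number from compound 3 to compound 4 (0.37 log units; beyond the scatter) is therefore toward a weaker inhibitor, with a fair chance that only a limit is returned. Compound 4 is expected to give about 120000 nM in this assay, with a range from 50000 nM to 300000 nM.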

Compound 4, half-maximal inhibitory concentration: > 100000 nM
Compound 4: only a limit was reported (the forecaster's own chance of this, stated with the estimate: 60%); the middle value does not contradict the limit.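

In this assay, swapping the aromatic groups on the amide-type nitrogen for a pentyl chain, with the rest of the molecule unchanged, gives an at least 1.9-fold higher number from compound 3 to compound 4 (0.28 log units; that floor lies within the scatter) and an at least 1.7-fold higher number from compound 2 to compound 4 (0.24 log units; that floor lies within the scatter). Both figures are only floors, and both lie within the scatter, so the data do not prove that removing the aromatic ring weakens the compound, although the true step could be larger. What compound 4 adds is that a pentyl chain on this nitrogen ends at a limit of the assay even with the same fluorine-bearing aromatic group that compound 2 and compound 3 carry, so the limit seen for compound 1 is no longer tied to methoxy alone: the limit of > 100000 nM in this assay, at which 2 of the 4 values shown sit.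

The step from compound 1 to compound 4, fluoro in place of methoxy on an aromatic carbon, cannot be read, since both results are limits, and the same gap hides how much that aromatic substituent matters with this chain in place. From the compounds shown here alone, it also remains open whether a shorter chain, or a chain carrying an amine or a carboxylic acid, in place of pentyl would return a measurable number.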